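From Dimethoxyphenyl to Methoxyphenyl: A Modest Shift Expected

A few compounds are considered here, and "the series" means these few. Any claim that something is new, unique, unknown or untested is made for them only; others in the source may bear on it.

Two compounds share a common core: compound 1 `COC(=O)/C=C/c1cccc(N(Cc2ccc(/C=C/c3cccc(C(F)(F)F)c3)cc2)C(=O)C(C)C)c1` and compound 2 `COC(=O)/C=C/c1cccc(N(Cc2ccc(-c3c(OC)cccc3OC)cc2)C(=O)C(C)C)c1`. In an assay on isolated protein with Bile acid receptor (Homo sapiens) as the target (a higher number here means that more compound is needed for the effect, a lower number that less compound is needed), compound 1 gives 267 nM, while compound 2 gives 95 nM. Going by the values given here, the only measured step, a 2.8-fold lower number from compound 1 to compound 2 (0.45 log units; beyond the scatter), leaves compound 2 with the lowest of the two numbers, with compound 1 as its nearest neighbour.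

Compound 3 `COC(=O)/C=C/c1cccc(N(Cc2ccc(-c3cccc(OC)c3)cc2)C(=O)C(C)C)c1` differs from compound 2 in one place: 3-methoxyphenyl in place of 2,6-dimethoxyphenyl on an aromatic carbon. Among the compounds with values here, no measured step bears directly on this change; the step from compound 1 to compound 2 concerns a different group and offers no guide to the loss of one methoxy substituent. With nothing more than a change between two methoxyphenyl groups to go on, the step of a 1.6-fold higher number from compound 2 to compound 3 (0.20 log units; within the scatter) is expected to be small, possibly within the scatter, perhaps slightly upward. The estimate for compound 3 in this assay is 150 nM, within a range of 50 nM to 450 nM.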

Compound 3, half-maximal effective concentration: 72 nM
Compound 3: the middle estimate sits 2.1-fold (0.32 log units) above what was measured, within the range that was stated.
By their numbers in this assay, from the lowest: compounds 3 and 2 (each within the scatter of the next); then compound 1.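

In this assay the aromatic carbon para to a large group accepts 3-methoxyphenyl in place of 2,6-dimethoxyphenyl with no change beyond the scatter (a 1.3-fold lower number from compound 2 to compound 3 (0.12 log units; within the scatter)), so the second methoxy group is not required to keep the number at this level. The gain over 2-(3-(trifluoromethyl)phenyl)ethenyl also holds with this smaller group (a 3.7-fold lower number from compound 1 to compound 3 (0.57 log units; beyond the scatter)), which shows that it does not depend on the 2,6-dimethoxy pattern. Nothing available explains why the two methoxyphenyl groups give values within the scatter of each other.

Whether any methoxy group is needed at all remains open, as a plain phenyl group is not among these compounds. It is also unknown how a hydroxyl group or an amine on this ring would read in this assay.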